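This account rests on a few compounds, and the source may have more. Where it says the series, first, only, none or still open, it means among the compounds named here.

The measured compounds in a functional assay on A549 cells (Homo sapiens) for cytotoxicity, read by MTT assay, with a stated time of 72 h (on this read-out lower numbers stand for stronger inhibition and higher numbers for weaker inhibition), are:

compound 1 `COc1cc2c(Oc3ccc(NC(=O)c4cn(-c5ccccc5F)nn4)cc3F)ccnc2cc1OCCCN1CCC(C)CC1`, which gives 250 nM;
compound 2 `COc1cc2c(Oc3ccc(NC(=O)c4cn(-c5c(C)cccc5C)nn4)cc3F)ccnc2cc1OCCCN1CCC(C)CC1`, which gives 3340 nM.

Among the measured compounds shown here, compound 2 stands at the higher of the two numbers: its nearest neighbour is compound 1, and the single measured step, a 13-fold higher number from compound 1 to compound 2 (1.13 log units; beyond the scatter), lies beyond the scatter and runs toward weaker inhibition. The unmeasured compound 3 `COc1cc2c(Oc3ccc(NC(=O)c4cn(-c5c(Cl)cccc5Cl)nn4)cc3F)ccnc2cc1OCCCN1CCC(C)CC1` differs from compound 2 in one place: 2,6-dichlorophenyl in place of 2,6-dimethylphenyl on an aromatic nitrogen. For the measured compounds named here, only the step from compound 1 to compound 2 bears on this change, and it concerns a different exchange, a 2-fluorophenyl giving way to a 2,6-dimethylphenyl; nothing among the measured compounds compares methyl with chlorine on that phenyl. Compound 2 and compound 3 both carry a phenyl bearing two groups in the same two positions, so the large step already seen is not expected to repeat; the step is estimated to be a 1.3-fold lower number from compound 2 to compound 3 (0.13 log units; within the scatter), within the scatter. Compound 3 is therefore expected to give about 2500 nM in this assay, between 800 nM and 8000 nM.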

Compound 3, half-maximal inhibitory concentration: 320 nM
For compound 3 the middle estimate is 7.8-fold (0.89 log units) above the measured one; the whole stated range lies above it.
By their numbers in this assay, from the lowest: compounds 1 and 3 (each within the scatter of the next); then compound 2.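

The earlier step, a 13-fold higher number from compound 1 to compound 2 (1.13 log units; beyond the scatter), could be read in this assay as what any phenyl with two groups costs at this place on the aromatic nitrogen, but the new result rules out that reading. The exchange of 2,6-dimethylphenyl for 2,6-dichlorophenyl gives a 10-fold lower number from compound 2 to compound 3 (1.02 log units; beyond the scatter), and the comparison with the singly substituted phenyl gives a 1.3-fold higher number from compound 1 to compound 3 (0.11 log units; within the scatter), so here the identity of the two groups matters, not merely their presence, and the 2,6-dimethylphenyl of compound 2 alone stands apart among the three. Nothing at hand explains why methyl and chlorine part so widely on this phenyl.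

As far as these compounds go, whether 2-chloro-6-methylphenyl would sit with compound 2 or with compound 3 remains open, as does where an unsubstituted phenyl or a 2,6-difluorophenyl would fall on the same aromatic nitrogen. Also open, from the compounds shown here alone, is whether the gap between the dimethyl and dichloro groups would persist with a different amine at the end of the propoxy chain, or on any read-out other than this assay.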